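Moving the ring nitrogen: pyridin-3-yl to pyridin-4-yl

The source may hold more compounds than are shown below. What is called first, only, known or untested is meant among the compounds shown, and "the series" means these compounds.

Measured compounds:
compound 1, `Fc1ccc(-c2csc(N/N=C\c3cccnc3)n2)cc1`, 40%
compound 2, `Fc1ccc(-c2csc(N/N=C\c3ccncc3)n2)cc1`, 40%
compound 3, `C/C(=N/Nc1nc(-c2ccc(F)cc2F)cs1)c1cccnc1`, 40%

All three were tested in an in vitro assay on BTI-TN-5B1-4 cells for inhibition of Amine oxidase [flavin-containing] A (Homo sapiens), read by Amplex Red, with a stated time of 15 min, tested at 100 uM; a lower number here means less inhibition, a higher number more inhibition at the concentration tested (going by the name of the read-out). Compound 1 gives 40%, and compound 2, which differs from it by pyridin-4-yl in place of pyridin-3-yl on a carbon with a double bond to nitrogen, gives 40%; the step of no change at the digits printed from compound 1 to compound 2 (within the scatter). Compound 3 carries a different core, and the difference between its core and that of compound 1 is not broken down here. In this assay compound 3 gives 40%, level with compounds 1 and 2 within the usual scatter.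

Compound 4, `C/C(=N/Nc1nc(-c2ccc(F)cc2F)cs1)c1ccncc1`, has not yet been measured. It differs from compound 3 by pyridin-4-yl in place of pyridin-3-yl on a carbon with a double bond to nitrogen. Around that place the two cases are not identical: in compound 4 the carbon with the double bond to nitrogen also carries a saturated chain carbon, so this is the same kind of change as from compound 1 to compound 2, not the same change. Because the earlier step of no change at the digits printed from compound 1 to compound 2 (within the scatter), the expected step is no change at the digits printed from compound 3 to compound 4 (within the scatter). Compound 4 is therefore estimated at 40%, with a range expected from 25% to 55%.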

Compound 4, a percentage reported as inhibition, at one concentration (the size of the read-out at that concentration, not a potency): 40%
Compound 4: middle estimate and measured number agree at the digits printed; low and high end bracket the measured number.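

In this assay, the swap of pyridin-3-yl for pyridin-4-yl on a carbon with a double bond to nitrogen gives the step of no change at the digits printed from compound 3 to compound 4 (within the scatter). Set beside the earlier step, the change behaves alike on both cores: the same change on two cores in this assay, no change at the digits printed (within the scatter) from compound 1 to compound 2 and no change at the digits printed (within the scatter) from compound 3 to compound 4, 0 percentage points apart, within the scatter of two such steps. This shows that, for these two pairs, the place of the ring nitrogen leaves the read-out at one concentration unchanged within the scatter, but it does not show how potent any of the four compounds is, nor that the same would hold on a third core or in another assay.

Every group at this place in the compounds shown is a pyridine ring joined through its 3 or 4 position, so the outcome with pyridin-2-yl, a plain phenyl ring or a pyridine ring bearing an amine stays open. Also open, from the compounds shown here alone, is whether a longer chain in place of the saturated chain carbon would move the read-out.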